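Swapping the acyl sulfonamide for a hydroxyethoxy tail

The compounds below may be only part of what the source reports. "The series", "measured", "known", "first", "only" and "open" are said of these compounds alone.

Of the compounds shown here, two share a core and have been tested in a functional assay on HEK293 cells for agonist activity at Bile acid receptor (Homo sapiens); on this read-out lower numbers stand for an effect already at smaller amounts and higher numbers for an effect only at larger amounts of compound. Compound 1 `CC(C)c1onc(-c2c(Cl)cccc2Cl)c1COc1ccc(N(C)C(=O)c2ccc(C(=O)O)cc2)c(C(F)(F)F)n1` gives 316 nM. Compound 2 `CC(C)c1onc(-c2c(Cl)cccc2Cl)c1COc1ccc(N(C)Cc2ccc(C(=O)NS(C)(=O)=O)cc2)c(C(F)(F)F)n1` gives 221 nM, the lower of the two numbers, though the gap to compound 1 is within the scatter. Compound 3 `CC(C)c1onc(-c2c(Cl)cccc2Cl)c1COc1ccc(N(C)Cc2ccc(OCCO)cc2)c(C(F)(F)F)n1` has not been measured yet. It differs from compound 2 in one place: 2-hydroxyethoxy in place of (methylsulfonyl)carbamoyl on an aromatic carbon. For the measured compounds named here, no measured pair shows what this change does, so the expectation rests only on compound 2 and its value of 221 nM. A loss beyond the scatter is expected, a 6.8-fold higher number from compound 2 to compound 3 (0.83 log units; beyond the scatter), giving compound 3 an estimated 1500 nM, between 400 nM and 6000 nM.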

Compound 3, half-maximal effective concentration: 1150 nM
Estimate against measurement, compound 3: 1.3-fold (0.12 log units) above; measured number inside the range.
By their numbers in this assay, from the lowest: compounds 2 and 1 (each within the scatter of the next); then compound 3.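

Placing 2-hydroxyethoxy in place of (methylsulfonyl)carbamoyl on this aromatic carbon gives a 5.2-fold higher number from compound 2 to compound 3 (0.72 log units; beyond the scatter), so the read-out is sensitive to which of these two groups sits here. Compound 3 also falls behind compound 1, with 4-(2-hydroxyethoxy)benzyl in place of (4-carboxyphenyl)carbonyl on the nitrogen giving a 3.6-fold higher number from compound 1 to compound 3 (0.56 log units; beyond the scatter). No measurement available here explains either loss. Still open, going by these compounds, is how a carboxylic acid or an amine on this same aromatic carbon would compare, and whether either would stay close to compound 2 or fall toward compound 3.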